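The source may hold more compounds than are shown below. What is called first, only, known or untested is meant among the compounds shown, and "the series" means these compounds.

Compound 1 `CC(C)(C)c1cn(C[C@H](O)[C@H]2OC(=O)C(OCc3ccccc3)=C2OCc2ccccc2)nn1` was tested in a functional assay on SW-620 cells (Homo sapiens) for antiproliferative activity, read by MTT assay, with a stated time of 72 h (on this read-out lower numbers stand for stronger inhibition and higher numbers for weaker inhibition), where compound 1 gives 35800 nM. Two relatives share the core but carry a different group at the same position. Compound 2 `O=C1O/C(=C\Cn2cc(-c3cc(F)cc(F)c3)nn2)C(OCc2ccccc2)=C1OCc1ccccc1` reaches only a limit in this assay, > 100000 nM. Compound 3 `O=C1O/C(=C\Cn2cc(-c3cccc(O)c3)nn2)C(OCc2ccccc2)=C1OCc1ccccc1` gives 69800 nM. Of the two numbers shown, compound 1 has the lower one, yet its gap to compound 3 lies within the scatter, so no order between them can be read. Among the measured compounds shown here, the only measured step, an at least 1.4-fold lower number from compound 2 to compound 3 (0.15 log units; that floor lies within the scatter), is small, and its size is set by a limit of > 100000 nM in this assay, at which 1 of the 3 values shown sits, rather than a number. Compound 4 `O=C1O[C@H]([C@@H](O)Cn2cc(-c3ccc(Br)cc3)nn2)C(OCc2ccccc2)=C1OCc1ccccc1` differs from compound 1 by 4-bromophenyl in place of tert-butyl on an aromatic carbon. For the measured compounds named here, no measured step exchanges tert-butyl for a ring group, so compounds 2 and 3 are the only guide, and neither gives a number lower than compound 1. The expected step is therefore a 1.4-fold higher number from compound 1 to compound 4 (0.15 log units; within the scatter), at most a little beyond the scatter toward a higher number. Compound 4 is estimated at 50000 nM, within 15000 nM to 150000 nM.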

Compound 4, half-maximal inhibitory concentration: 3760 nM
Compound 4: the middle estimate sits 13-fold (1.12 log units) above what was measured; measured number outside the range, below it.
By their numbers in this assay, from the lowest: compound 4; then compounds 1 and 3 (each within the scatter of the next). At a limit, above all of these: compound 2.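

Exchanging tert-butyl for 4-bromophenyl gives a 9.5-fold lower number from compound 1 to compound 4 (0.98 log units; beyond the scatter) in this assay, and this is the only step shown that lies beyond the scatter. It shows that the group on this aromatic carbon can clearly change the number, and that a ring group here can give a lower number than tert-butyl. Compounds 2 and 3 could not show this, as they also differ from compound 1 in the link to the core. Nothing among the data shown accounts for the size of this step.

Whether the lower number goes with the ring itself or with the bromine stays open, as the compounds shown do not pair the core of compound 4 with a plain phenyl or a 4-chlorophenyl group. Also open, going by these compounds, is how an amine or a carboxylic acid on that ring, or a longer chain in its place, would read in this assay.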